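Pyridin-2-yl on the carbonyl of compound 2: working notes

The source may hold more compounds than are shown below. What is called first, only, known or untested is meant among the compounds shown, and "the series" means these compounds.

Measured so far in a functional assay on MCF7 cells (Homo sapiens) for antiproliferative activity, with a stated time of 5 days (a higher number here means a weaker inhibitor, a lower number a stronger inhibitor), for this series:
compound 1 `CCCCc1ccc2[nH]c(-c3ccc(OC)cc3)c(/C=N/NC(=O)c3ccc(OC)cc3)c2c1` gives 226 nM
compound 2 `CCCCc1ccc2[nH]c(-c3ccc(C(F)(F)F)cc3)c(/C=N/NC(=O)c3ccc(OC)cc3)c2c1` gives 618 nM
compound 3 `CCCCc1ccc2[nH]c(-c3ccc(OC)cc3)c(/C=N/NC(=O)c3ccc([N+](=O)[O-])cc3)c2c1` gives 312 nM

Only one gap in this set lies beyond the scatter, the step of a 2.7-fold higher number from compound 1 to compound 2 (0.44 log units; beyond the scatter) with trifluoromethyl in place of methoxy on an aromatic carbon. Compound 2 at 618 nM and compound 3 at 312 nM lie within the scatter of each other, so compound 2 stands apart from compound 1 alone.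

The next step leads to compound 4 `CCCCc1ccc2[nH]c(-c3ccc(C(F)(F)F)cc3)c(/C=N/NC(=O)c3ccccn3)c2c1` with pyridin-2-yl in place of 4-methoxyphenyl on a carbonyl carbon as the counted difference, in words pyridin-2-yl in place of 4-methoxyphenyl on a carbonyl carbon. The nearest evidence is the step of a 1.4-fold higher number from compound 1 to compound 3 (0.14 log units; within the scatter) where nitro replaces methoxy within that same 4-methoxyphenyl group and the change stays within the scatter. The step of a 2.7-fold higher number from compound 1 to compound 2 (0.44 log units; beyond the scatter) falls elsewhere in the molecule and bears on this change only weakly. For the measured compounds named here, no measured compound carries pyridin-2-yl, so the evidence is thin and the range stays wide.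

The expected step is a 1.0-fold lower number from compound 2 to compound 4 (0.01 log units; within the scatter) and no change beyond the scatter is foreseen in this assay with neither direction favoured. The estimated value of compound 4 is 600 nM with an expected range from 230 nM to 1600 nM at this stage.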

Compound 4, half-maximal inhibitory concentration: 310 nM
Estimate against measurement, compound 4: 1.9-fold (0.29 log units) above, and the stated range covers the measured number.
By their numbers in this assay, from the lowest: compounds 1, 4, 3 and 2 (each within the scatter of the next, the first and the last beyond it).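

In this assay, the 4-methoxyphenyl on the carbonyl carbon can be replaced whole by pyridin-2-yl, a six-membered aromatic ring with a hetero atom, and the step (a 2.0-fold lower number from compound 2 to compound 4 (0.30 log units; within the scatter)) stays within the scatter. The earlier change at this end of the molecule (a 1.4-fold higher number from compound 1 to compound 3 (0.14 log units; within the scatter)) only exchanged methoxy for nitro on the same phenyl ring and carried the 4-methoxyphenyl on the other side of the core, so tolerance here now extends to the ring itself and to a partner bearing trifluoromethyl. Nothing at hand explains why these two changes at the carbonyl stay within the scatter while the trifluoromethyl step on the other aryl group does not.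

The compounds shown leave open whether pyridin-2-yl gives the same result when the other aryl group carries methoxy, which would separate this change from the trifluoromethyl background. They also leave open how pyridin-3-yl, pyridin-4-yl or a phenyl ring bearing an amine or a carboxylic acid would read at the carbonyl, and whether a longer chain in place of butyl would alter the picture.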